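The source may hold more compounds than are shown below. What is called first, only, known or untested is meant among the compounds shown, and "the series" means these compounds.

Measured in a functional assay on MDA-MB-231 cells (Homo sapiens) for cytotoxicity, read by MTT assay; a lower number here means a stronger inhibitor, a higher number a weaker inhibitor:

Compound 1, `COc1cccc(/C=C2\CCC/C(=C\c3cccc([N+](=O)[O-])c3)C2=O)c1`, gives 13.2 ug/mL.
Compound 2, `COc1cccc(/C=C2\CCC/C(=C\c3cccc([N+](=O)[O-])c3)C2=O)c1OC`, gives 5.59 ug/mL.
Compound 3, `CCOc1c(Br)cc(/C=C2\CCC/C(=C\c3cccc([N+](=O)[O-])c3)C2=O)cc1OC`, gives 19.3 ug/mL.

Compound 2 holds the lowest number of the three in this assay: compound 1 is the nearest to it and compound 3 the furthest, both steps beyond the scatter. Among the compounds with values here, the one step within this set that joins two compounds differing in a single place is a 2.4-fold lower number from compound 1 to compound 2 (0.37 log units; beyond the scatter), a modest change.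

Compound 4, `COc1cccc(/C=C2\CCC/C(=C\c3ccc([N+](=O)[O-])cc3)C2=O)c1OC`, is not yet measured in this assay. It differs from compound 2 in this way: 4-nitrophenyl in place of 3-nitrophenyl on a double-bonded chain carbon bound to a double-bonded ring carbon. No measured pair in the set shows the same change, so nothing among the shown steps bears directly on it; the only step, from compound 1 to compound 2, concerns a methoxy group on the other ring. With no guide in the data, the expected change is none beyond the scatter, and a 1.0-fold lower number from compound 2 to compound 4 (0.01 log units; within the scatter) is what that expectation amounts to. Compound 4 is therefore estimated at 5.5 ug/mL in this assay, with a range from 2.5 ug/mL to 12 ug/mL.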

Compound 4, half-maximal inhibitory concentration: 6.73 ug/mL
Beside the measured number, compound 4's estimate is 1.2-fold (0.09 log units) below it, within the range that was stated.
By their numbers in this assay, from the lowest: compounds 2, 4, 1 and 3 (each within the scatter of the next, the first and the last beyond it).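

In this assay, 4-nitrophenyl in place of 3-nitrophenyl on a double-bonded chain carbon bound to a double-bonded ring carbon gives a 1.2-fold higher number from compound 2 to compound 4 (0.08 log units; within the scatter), so in this pair the change leaves no readable difference. Within the data shown here, the earlier step concerned a methoxy group on the other ring, whereas this one is the first to touch the nitrophenyl side, and it shows that the two nitrophenyl forms are not told apart with the rest of compound 2 held fixed. No supporting data are available to explain this result.

On these data alone, whether an amine or a carboxylic acid in place of the nitro group would also leave the number unchanged stays open. So does whether the same change would read alike on the other ring of compound 1 or compound 3.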